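Dropping Both Methyls from the Amide Pyridine

The source may report more compounds than this note shows. Statements on the series, on what has been measured and on what is new or still open speak of the compounds shown alone.

Measured so far:
compound 1 `Cc1nc(C(F)(F)F)ccc1C(=O)Nc1ccc(Cl)c(-c2cnccn2)c1`, 1700 nM
compound 2 `Cc1nc(C(F)(F)F)ccc1C(=O)Nc1ccc(Cl)c(-c2cnc3ccccc3n2)c1`, 52 nM
compound 3 `Cc1ccc(C(=O)Nc2ccc(Cl)c(-c3ccccn3)c2)c(C)n1`, 130 nM

The three compounds were tested in an assay on C3H 10T1/2 cells for inhibition of Sonic hedgehog protein (Mus musculus), read by a luciferase reporter; on this read-out lower numbers stand for stronger inhibition and higher numbers for weaker inhibition. Compound 3 stands second highest of the three numbers: its nearest neighbour is compound 2, whose number is lower, and its furthest is compound 1, whose number is higher. Among the compounds with values here, the one step that can be read between two compounds differing in a single place is a 33-fold lower number from compound 1 to compound 2 (1.51 log units; beyond the scatter); it concerns the group on the aromatic carbon of the core, not the amide side.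

Compound 4 `O=C(Nc1ccc(Cl)c(-c2ccccn2)c1)c1cccnc1` differs from compound 3 by the change (pyridin-3-yl in place of 2,6-dimethylpyridin-3-yl on a carbonyl carbon). Within the data shown here, no measured step bears on this change, since compounds 1 and 2 carry yet another group on that carbonyl carbon, so no direction can be taken from the data. The expected step is a 4.6-fold higher number from compound 3 to compound 4 (0.66 log units; beyond the scatter), with wide uncertainty. Compound 4 is estimated to give 600 nM in this assay, within a range from 120 nM to 3000 nM.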

Compound 4, half-maximal inhibitory concentration: 600 nM
Compound 4: the middle estimate sits on the measured number at the digits printed, and the stated range covers the measured number.
By their numbers in this assay, from the lowest: compound 2; then compound 3; then compound 4; then compound 1.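

In this assay, within the data shown here, pyridin-3-yl in place of 2,6-dimethylpyridin-3-yl on a carbonyl carbon gives a 4.6-fold higher number from compound 3 to compound 4 (0.66 log units; beyond the scatter), the first measured evidence that inhibition responds to a change at this position. The change leaves the six-membered aromatic ring, its hetero atom and its hydrogen-bond counts as they were, and takes the heavy atoms from 8 to 6, so the higher number goes with the loss of the two methyl groups, though the step is smaller than a 33-fold lower number from compound 1 to compound 2 (1.51 log units; beyond the scatter) on the aromatic carbon. Nothing available accounts for the step.

Going by these compounds, whether one methyl group alone would keep the lower number remains open, as does the effect of a chlorine atom or a methoxy group on the same ring. Compounds 1 and 2 also cannot be tied to this step, since they differ from compounds 3 and 4 in more than one place.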